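The source may report more compounds than this note shows. Statements on the series, on what has been measured and on what is new or still open speak of the compounds shown alone.

Working notes on the step to compound 4. In an ADME assay on NCM460 cells (Homo sapiens) for cytotoxicity, read by CCK-8 assay, with a stated time of 48 h (a higher number here means a weaker inhibitor, a lower number a stronger inhibitor), compound 3 `COc1ccc(/C=C\c2cc(OC)c(OC)c(OC)c2)cc1OCc1ccc(CN2CC[C@@H](C(=O)O)C2)cc1` gives > 50000 nM, which is a limit of the assay and not a number. Compound 1 `COc1ccc(/C=C\c2cc(OC)c(OC)c(OC)c2)cc1OCc1ccc(CN[C@H](C(=O)O)[C@H](C)O)cc1` gives > 50000 nM, again a limit. Both therefore sit at the limit of > 50000 nM in this assay, at which 2 of the 3 values shown sit. Going by the values given here, compound 2 `COc1ccc(/C=C\c2cc(OC)c(OC)c(OC)c2)cc1OCc1ccc(CNCCN(C)C)cc1` is the only one with a number, 35000 nM, and the only one of the three without carboxy.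

Compound 4 `COc1ccc(/C=C\c2cc(OC)c(OC)c(OC)c2)cc1OCc1ccc(CN2CC[C@@H](O)C2)cc1` has hydroxy in place of carboxy on a saturated ring carbon.

Among the compounds with values here, three measured steps bear on this. They are an at least 1.4-fold lower number from compound 1 to compound 2 (0.15 log units; that floor lies within the scatter), an at least 1.4-fold higher number from compound 2 to compound 3 (0.15 log units; that floor lies within the scatter) and a step that the two limits leave unreadable from compound 1 to compound 3. None gives a firm size, and none changes the same group as compound 4 does. Within the data shown here, the only guide is compound 2 at 35000 nM, so a small move to a lower number is expected in this assay, possibly within the scatter. A result at the limit remains likely. The expected step is an at least 1.2-fold lower number from compound 3 to compound 4 (0.09 log units; that floor lies within the scatter). For compound 4 the estimated value is 40000 nM, with an expected range of 18000 nM to 70000 nM.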

Compound 4, half-maximal inhibitory concentration: 53000 nM
The estimate for compound 4 lay 1.3-fold (0.12 log units) below the measured number, within the range that was stated.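

In this assay, compound 4 gives a readable number, so the pyrrolidine ring now has a member without carboxy that reads on the scale. Replacing (2-(dimethylamino)ethyl)amino with 3-hydroxypyrrolidin-1-yl gives a 1.5-fold higher number from compound 2 to compound 4 (0.18 log units; within the scatter), so the two compounds without carboxy cannot be told apart here. The steps to compound 4 from compound 3 and from compound 1 cannot be read, and the effect of hydroxy in place of carboxy on this ring carbon therefore stays unsized, because those two compounds sit at a limit: the limit of > 50000 nM in this assay, at which 2 of the 4 values shown sit.

Open, going by these compounds, is how an amine or an amide on the same saturated ring carbon would read in this assay. Also open, on these data alone, is whether any group at this place gives a number clearly apart from those of compound 2 and compound 4.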